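Ester series in simulated gastric fluid: methyl additions

A few compounds are considered here, and "the series" means these few. Any claim that something is new, unique, unknown or untested is made for them only; others in the source may bear on it.

Measured compounds and their values in a physicochemical assay for metabolic stability, read by LC-MS, in simulated gastric fluid, with a stated time of 15 min, tested at 50 uM; on this read-out higher numbers stand for a more stable compound and lower numbers for a less stable compound:
compound 1 `Cc1cccc(OC(=O)c2coc(-c3ccccc3)n2)c1C` — 2%
compound 2 `Cc1ccccc1OC(=O)c1coc(-c2ccccc2)n1` — 1.5%
compound 3 `Cc1ccc(COC(=O)c2coc(-c3ccccc3)n2)c(C)c1` — 1.4%

All three numbers sit close together and low, and none of the gaps between them is beyond the usual scatter. Compound 3 has the lowest of the three numbers, with compound 2 nearest and compound 1 furthest, both within the scatter; so no order among the three is claimed.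

One change recurs. From compound 2 to compound 1 it is methyl in place of hydrogen on an aromatic carbon, and it gives a number 0.5 percentage points higher from compound 2 to compound 1 (within the scatter). The same kind of change leads from compound 3 to the unmeasured compound 4 `Cc1cc(C)c(COC(=O)c2coc(-c3ccccc3)n2)c(C)c1`: methyl in place of hydrogen on an aromatic carbon. It is not the same change, since the surroundings differ: in compound 1 the new methyl is ortho to a methyl group and meta to a large group, whereas in compound 4 it is ortho to a large group and meta to two methyl groups. The difference between the core of compound 2 and the core of compound 3 is not broken down here; only their two values are known, and they lie within the scatter of each other.

For compound 4 in this assay the expected step is a number 0.2 percentage points higher from compound 3 to compound 4 (within the scatter), resting on the step from compound 2 to compound 1 being a number 0.5 percentage points higher from compound 2 to compound 1 (within the scatter) and on compound 3 giving 1.4%. Compound 4 is therefore estimated at 1.6%, with a range from 0.3% to 5%.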

Compound 4, percent of the compound remaining: 5.6%
Compound 4: middle estimate off by 4 percentage points, on the low side; measured number outside the range, above it.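

In this assay methyl in place of hydrogen on an aromatic carbon gives a number 4.2 percentage points higher from compound 3 to compound 4 (within the scatter) and on the other core gives a number 0.5 percentage points higher from compound 2 to compound 1 (within the scatter) so on each core the change stays within the usual scatter. This does not show that the change carries a reliable effect of its own from one core to the other, and it does not show that the core or the surroundings alter its size, since each core offers a single pair and the new methyl of compound 4 sits ortho to a large group and meta to two methyl groups. Nothing available bears on what lies behind either step.

The compounds shown vary the aromatic ring only through methyl, so the same place carrying an ethyl group, a longer chain, a methoxy group, an amine or a carboxylic acid remains open. Also open, going by these compounds, is whether the step would hold on a third core, or on repeated measurement of these same two pairs.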